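The compounds below may be only part of what the source reports. "The series", "measured", "known", "first", "only" and "open" are said of these compounds alone.

Measured in an ADME assay on microsomes from liver (Homo sapiens) for metabolic stability; on this read-out lower numbers stand for slow clearance and higher numbers for fast clearance:
- Compound 1 `CC(=O)N[C@@H]1CCC[C@H](C(=O)Nc2cc(-c3cnn(C)c3C)c(Cl)cn2)C1`: 3.3 mL.min-1.g-1.
- Compound 2 `CC(=O)N[C@@H]1CCC[C@H](C(=O)Nc2cc(-c3cnn4c3CN(C)CC4)c(Cl)cn2)C1`: < 3 mL.min-1.g-1, a limit of the assay.
- Compound 3 `CC(=O)N[C@@H]1CCC[C@H](C(=O)Nc2cc(-c3cnn4c3CC(C)C4)c(Cl)cn2)C1`: 13 mL.min-1.g-1; 18 mL.min-1.g-1 (2 entries).

For compound 2 there is only a limit, not a number: the limit of < 3 mL.min-1.g-1 in this assay, at which 1 of the 3 values shown sits. Among the measured compounds shown here, the one measured step is an at least 1.1-fold lower number from compound 1 to compound 2 (0.04 log units; that floor lies within the scatter).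

Compound 4 `CC(=O)N[C@@H]1CCC[C@H](C(=O)Nc2cc(-c3cnc4n3CC(C)(C)C4)c(Cl)cn2)C1` carries a new group on the same aromatic carbon: a group of 10 heavy atoms (8 carbon, 2 nitrogen; one five-membered non-aromatic ring with 1 hetero atom, one five-membered aromatic ring with 2 hetero atoms) in place of a group of 10 heavy atoms (7 carbon, 3 nitrogen; one five-membered aromatic ring with 2 hetero atoms, one six-membered non-aromatic ring with 2 hetero atoms), on an aromatic carbon. That step gives little guidance on this change. The closer guide is compound 3, which also has a five-membered non-aromatic ring and gives 13 mL.min-1.g-1; 18 mL.min-1.g-1 (2 entries). A move towards a higher number is therefore expected, though less certainly than a measured step would show. The estimated step is an at least 3.0-fold higher number from compound 2 to compound 4 (0.47 log units; beyond the scatter). Compound 4 is expected at 9 mL.min-1.g-1, with an estimated range of 3.5 mL.min-1.g-1 to 24 mL.min-1.g-1.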

Compound 4, intrinsic clearance in microsomes: 63 mL.min-1.g-1
Beside the measured number, compound 4's estimate is 7.0-fold (0.85 log units) below it; measured number above the stated range.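

In this assay, changing the group on this aromatic carbon, opposite the ring nitrogen, can move the number a long way, which the earlier step did not show: there is an at least 21-fold higher number from compound 2 to compound 4 (1.32 log units; beyond the scatter), and a 19-fold higher number from compound 1 to compound 4 (1.28 log units; beyond the scatter). Compound 2 has only a limit of the assay, < 3 mL.min-1.g-1. The leaving and entering groups both have 10 heavy atoms, so that count does not separate them. The compounds shown leave open which part of the entering group goes with the higher number. They also leave open whether a hydroxyl on its five-membered non-aromatic ring would lower it.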